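The compounds below may be only part of what the source reports. "The series", "measured", "known", "first", "only" and "open" are said of these compounds alone.

Working notes on the series.

Compound 1 `COc1ccc2ncc(C(=O)O)cc2c1` is the parent. In a functional assay on the whole organism (strain Sprague-Dawley) for inhibition, with Rattus norvegicus as the target (on this read-out higher numbers stand for an effect only at larger amounts of compound and lower numbers for an effect already at smaller amounts), compound 1 is reported only as a limit, > 5 mg/kg. Compound 2 `COc1ccc2ncc(C(=O)O)c(O)c2c1` carries the change hydroxy in place of hydrogen on an aromatic carbon on the core of compound 1. In this assay compound 2 likewise is reported only as a limit, > 50 mg/kg. The step that the two limits leave unreadable from compound 1 to compound 2 therefore cannot be read in size from these two limits, as the limit of > 5 mg/kg in this assay, at which 1 of the 3 values shown sits, and the limit of > 50 mg/kg in this assay, at which 1 of the 3 values shown sits, together show.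

Compound 3 `COc1ccc2cc(C(=O)O)cnc2c1` has the same atoms as compound 1 joined differently; the difference between the two cores is not broken down here. In this assay, for the measured compounds named here, compound 3 again is reported only as a limit, > 25 mg/kg, which is what the limit of > 25 mg/kg in this assay, at which 1 of the 3 values shown sits, records; every value so far is a limit.

Compound 4 `COc1ccc2c(O)c(C(=O)O)cnc2c1`, not yet measured, carries the change hydroxy in place of hydrogen on an aromatic carbon on the core of compound 3, the same change as that from compound 1 to compound 2. Since the step from compound 1 to compound 2 was unreadable and compound 3 gives only a limit, compound 4 is expected to show a step that the limit leaves unreadable from compound 3 to compound 4 in this assay, most likely again as a limit. Compound 4 is estimated at 60 mg/kg, between 25 mg/kg and 150 mg/kg.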

Compound 4, minimum effective dose: > 50 mg/kg
Compound 4: no number, only a limit; the forecaster's own chance of this, stated with the estimate: 85%; the middle value does not contradict the limit.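

Compound 4 in this assay is reported only as a limit, > 50 mg/kg. Compound 3 is also only a limit, so the step between compound 3 and compound 4 cannot be read in size. With all four values being limits, the compounds shown leave open the actual minimum effective dose of each compound and the size of any effect of the hydroxy change.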